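Swapping the Aryl on the Propanoyl Chain of Compound 3

The compounds below may be only part of what the source reports. "The series", "measured", "known", "first", "only" and "open" are said of these compounds alone.

Compound 3 `CC(C)C[C@H](N)c1cc(C(F)(F)F)ccc1N1CCN(C(=O)CCc2cccc(C(F)(F)F)c2)CC1` gives 2200 nM in an assay on HEK293 cells for displacement of a labelled ligand from Melanocortin receptor 4 (Homo sapiens) (a higher number here means a weaker inhibitor, a lower number a stronger inhibitor), the highest of the numbers measured here. Compound 1 `CCCCC(N)c1cc(C(F)(F)F)ccc1N1CCN(C(=O)CCc2ccc(Cl)cc2Cl)CC1` gives 190 nM, and compound 2 `CCC(C)C(N)c1cc(C(F)(F)F)ccc1N1CCN(C(=O)CCc2ccc(Cl)cc2Cl)CC1` gives 160 nM; the step of a 1.2-fold lower number from compound 1 to compound 2 (0.07 log units; within the scatter) lies within the scatter. Compound 4 `COc1ccc(CCC(=O)N2CCN(c3ccc(C(F)(F)F)cc3[C@@H](N)CC(C)C)CC2)cc1` differs from compound 3 by 4-methoxyphenyl in place of 3-(trifluoromethyl)phenyl on a saturated chain carbon, two bonds along the chain from a carbonyl carbon. Within the data shown here, no measured step touches this place: compounds 1 and 2 carry a different aryl on the chain and also another alkyl group on the amine-bearing carbon, so their lower values cannot be assigned to the aryl alone. Among the measured compounds shown here, the only measured step sits elsewhere and is within the scatter. The expected step of a 1.2-fold lower number from compound 3 to compound 4 (0.09 log units; within the scatter) for compound 4 is therefore of uncertain size and direction. Compound 4 is estimated at 1800 nM, between 400 nM and 8000 nM.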

Compound 4, inhibition constant: 350 nM
Compound 4: middle estimate off by 5.1-fold (0.71 log units), on the high side; measured number below the stated range.
By their numbers in this assay, from the lowest: compounds 2, 1 and 4 (each within the scatter of the next, the first and the last beyond it); then compound 3.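

In this assay, the group on a saturated chain carbon, two bonds along the chain from a carbonyl carbon, proves able to move the number: 4-methoxyphenyl in place of 3-(trifluoromethyl)phenyl gives a 6.3-fold lower number from compound 3 to compound 4 (0.80 log units; beyond the scatter). Among these compounds, this is the first step read at this place, and it lies beyond the scatter. No available evidence explains it.

The step changes both the substituent and its ring position, so the two remain unseparated. A 3-methoxyphenyl or 4-(trifluoromethyl)phenyl group would address this, while a 4-hydroxyphenyl group at this place remains an open case.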